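Chromone acrylamides: a halogen swap on the anilide ring

This account rests on a few compounds, and the source may have more. Where it says the series, first, only, none or still open, it means among the compounds named here.

Measured compounds:
- compound 1, `COc1ccc2c(=O)c(/C=C/C(=O)Nc3ccc(Cl)cc3)coc2c1`: > 100000 nM in a functional assay on A549 cells (Homo sapiens) for inhibition, read by MTT assay, with a stated time of 48 h; a lower number here means a stronger inhibitor, a higher number a weaker inhibitor
- compound 2, `COc1cccc(NC(=O)/C=C/c2coc3cc(OC)ccc3c2=O)c1`: 12800 nM

Compound 1 stands at the edge of what this assay reports. Its value, > 100000 nM, is a limit of the assay and not a number; it is the point (the limit of > 100000 nM in this assay, at which 1 of the 2 values shown sits). Among the compounds with values here, compound 2, the one other compound measured here, gives 12800 nM, so the step of an at least 7.8-fold lower number from compound 1 to compound 2 (0.89 log units; beyond the scatter) is the only measured step in the set, and it exchanges the whole aryl group on the amide-type nitrogen.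

Compound 3, `COc1ccc2c(=O)c(/C=C/C(=O)Nc3ccc(F)cc3)coc2c1`, has not been measured. It differs from compound 1 in a smaller way: fluoro in place of chloro on an aromatic carbon. Within the data shown here, no measured step touches this change; the step from compound 1 to compound 2 concerns a different group and cannot be carried across. With compound 1 at a limit, the expected step of an at least 1.4-fold lower number from compound 1 to compound 3 (0.15 log units; that floor lies within the scatter) is small and uncertain, and compound 3 may also return only a limit. The estimate for compound 3 is 70000 nM, within 15000 nM to 300000 nM.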

Compound 3, half-maximal inhibitory concentration: 26800 nM
Compound 3: the middle estimate sits 2.6-fold (0.42 log units) above what was measured, and the stated range covers the measured number.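

In this assay, fluoro in place of chloro on an aromatic carbon para to a large group gives an at least 3.7-fold lower number from compound 1 to compound 3 (0.57 log units; beyond the scatter), so this one position alone can separate a compound at the limit from one with a measured number, without exchanging the whole aryl group. Going by these compounds, the full size of this step stays unknown, because compound 1 stands at a limit of the assay and not at a number: the limit of > 100000 nM in this assay, at which 1 of the 3 values shown sits. Set against the 3-methoxyphenyl group, the 4-fluorophenyl group gives a 2.1-fold higher number from compound 2 to compound 3 (0.32 log units; beyond the scatter), a modest step, so the halogen swap recovers a measured number but does not reach the value of compound 2.

The compounds shown leave open how other groups at this same place would read, and whether bromo, a methoxy group or an amine in place of fluoro would return a number or only a limit. Within the data shown here, they also leave open whether the difference between chloro and fluoro would hold on a core other than the one shared by compound 1 and compound 3.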